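Swapping a fluoro for a nitro on the aryl ring

This account rests on a few compounds, and the source may have more. Where it says the series, first, only, none or still open, it means among the compounds named here.

Two compounds share one core and differ only in the aryl group attached to it. In a functional assay on CHO cells for agonist activity at adenosine receptor A1 (Homo sapiens), read by fluorescence and ERK phosphorylation, with stated times of 30 min and 1.5 h, tested at 10 uM (on this read-out higher numbers stand for a stronger effect at the one concentration tested and lower numbers for a weaker effect), compound 1 `Nc1scc(-c2ccc(F)cc2)c1C(=O)c1ccccc1` gives 60%, while compound 2 `Nc1scc(-c2cccc(Br)c2)c1C(=O)c1ccccc1` gives 76%. Going by the values given here, on these two numbers compound 1 stands lowest, and the step of a number 16 percentage points higher from compound 1 to compound 2 (beyond the scatter) is the only measured step that bears on changes at this ring.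

Compound 3 `Nc1scc(-c2ccc([N+](=O)[O-])cc2)c1C(=O)c1ccccc1` is not yet measured. It arises from compound 1 by the change (nitro in place of fluoro on an aromatic carbon). Among the compounds with values here, the one measured step shows that altering the aryl substituent can move the read-out in this assay by a modest amount, but it involved a different group at a different place, so it guides the size of the expected step more than its direction. A step of about a number 5 percentage points higher from compound 1 to compound 3 (within the scatter) is therefore expected, small and uncertain in sign. For compound 3 the value in this assay is estimated at 65%, with a range from 45% to 85%.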

Compound 3, a percentage reported as activity, at one concentration (the size of the read-out at that concentration, not a potency): 47%
Compound 3: the middle estimate sits 18 percentage points above what was measured, within the range that was stated.
By their numbers in this assay, from the lowest: compound 3; then compound 1; then compound 2.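

Putting nitro in place of fluoro on this aromatic carbon, para to a large group, gives a number 13 percentage points lower from compound 1 to compound 3 (beyond the scatter) in this assay. The earlier step, a number 16 percentage points higher from compound 1 to compound 2 (beyond the scatter), changed both the group and where it sits, whereas this one changes only the group, so it shows that the read-out responds to the substituent at this carbon alone. Together the two steps also show that a change on this ring can lower the number as well as raise it, and no measurement shown here explains why nitro gives the lower number.

On these data alone, with only fluoro and nitro compared at this carbon, it remains open whether an amine or a methoxy group there would stay close to the fluoro compound or fall with the nitro compound. A bromo group on this same carbon would help settle whether the higher number of compound 2 belongs to the bromo itself or to its different place on the ring.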